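The compounds below may be only part of what the source reports. "The series", "measured", "known", "first", "only" and "open" are said of these compounds alone.

Among the compounds with values here, three related compounds have numbers so far in a functional assay on KB cells (Homo sapiens) for cytotoxicity, read by MTT assay, with a stated time of 72 h; a higher number here means that more compound is needed for the effect, a lower number that less compound is needed. Compound 1 `CCc1cccc2c(O)c(-c3occ(C)c3C(=O)O)ccc12` gives 9.1 ug/mL, compound 2 `CCOC(=O)c1c(C)coc1-c1ccc2c(CC)cccc2c1OC` gives 2.2 ug/mL and compound 3 `CCOc1c(-c2occ(C)c2C(=O)OC)ccc2c(CC)cccc12` gives 1.8 ug/mL. Compound 2 therefore stands level with compound 3, the two lying within the usual scatter, while compound 1 needs clearly more compound than compound 2 does.

Compound 4 `CCc1cccc2c(OC)c(-c3occ(C)c3CO)ccc12` has not yet been measured. It keeps the rest of compound 2 but carries hydroxymethyl in place of ethoxycarbonyl on an aromatic carbon. Within the data shown here, no measured pair shows this change on its own, so any expectation is rough. Among the measured compounds shown here, the nearest hint is compound 1, the one compound here without an ester, which shows 9.1 ug/mL, whereas compound 2 shows 2.2 ug/mL. Compound 1 differs from compound 2 in more than one place, however, so only a modest move toward a higher number is expected. The estimated change is a 1.8-fold higher number from compound 2 to compound 4 (0.26 log units; within the scatter), which may not clear the scatter. For compound 4 the expected value is 4 ug/mL, with an estimated range from 1.5 ug/mL to 11 ug/mL.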

Compound 4, concentration for half-maximal effect: 7.1 ug/mL
For compound 4 the middle estimate is 1.8-fold (0.25 log units) below the measured one, and the stated range covers the measured number.
By their numbers in this assay, from the lowest: compounds 3 and 2 (each within the scatter of the next); then compounds 4 and 1 (each within the scatter of the next).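

Within the data shown here, replacing ethoxycarbonyl with hydroxymethyl on this aromatic carbon of the five-membered ring gives the first comparison in this assay that changes only one place, with a 3.2-fold higher number from compound 2 to compound 4 (0.51 log units; beyond the scatter). Among these compounds, with the rest of compound 2 held fixed, this change means that more compound is needed for the effect, something the earlier compounds could not show because each differed from compound 2 in more than one place. No measurement shown here accounts for the size of this step.

As far as these compounds go, it remains open whether the higher number comes from losing the ester or from the hydroxymethyl itself. A methyl ester, a carboxylic acid or an amide at this carbon, with the rest of compound 2 unchanged, would help to separate these two readings.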